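A Methoxy Group Added to Two Related Cores

The source may report more compounds than this note shows. Statements on the series, on what has been measured and on what is new or still open speak of the compounds shown alone.

Of the compounds shown here, three have so far been tested in a functional assay on RKO cells (Homo sapiens) for cytotoxicity, read by resazurin assay, with a stated time of 72 h; a lower number here means a stronger inhibitor, a higher number a weaker inhibitor. Compound 1 `c1ccc(Nc2nc(-n3cnc4ccccc43)cs2)cc1` and compound 3 `COc1ccc(Nc2nc(-n3cnc4ccccc43)cs2)cc1` share one core, while compound 2 `Cc1nccn1-c1csc(Nc2ccccc2)n1` is built on another core; the difference between the two cores is not broken down here. In this assay compound 1 gives > 100000 nM, which is a limit of the assay rather than a number. In this assay compound 3 gives > 100000 nM, again a limit. In this assay compound 2 gives > 100000 nM, also a limit. The whole picture is summed up by the limit of > 100000 nM in this assay, at which 3 of the 3 values shown sit.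

The change from compound 1 to compound 3 is methoxy in place of hydrogen on an aromatic carbon, and the step it made is a step that the two limits leave unreadable from compound 1 to compound 3. Compound 4 `COc1cccc(Nc2nc(-n3ccnc3C)cs2)c1`, not yet measured, differs from compound 2 by methoxy in place of hydrogen on an aromatic carbon. The two places are not the same word for word: in compound 3 the methoxy sits para to a large group, in compound 4 meta to a large group, so this is the same kind of change, not the same change.

In this assay compound 4 is expected to give about 150000 nM, with a likely range from 50000 nM to 500000 nM. The expected step is a step that the limit leaves unreadable from compound 2 to compound 4. This expectation rests on compound 2, because its value in this assay is > 100000 nM, a limit. It also rests on the earlier step of the same kind, a step that the two limits leave unreadable from compound 1 to compound 3, whose size could not be read.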

Compound 4, half-maximal inhibitory concentration: > 100000 nM
Compound 4: a limit, no number (the forecaster's own chance of this, stated with the estimate: 85%); the middle value lies beyond the limit too.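

Compound 2 and compound 4 each give only a limit of the assay, not a number, in this assay, so no size can be read for the step between them, and the whole set comes down to one entry: the limit of > 100000 nM in this assay, at which 4 of the 4 values shown sit.

The compounds shown leave open whether methoxy in place of hydrogen on an aromatic carbon changes cytotoxicity on either core, and what a measurable value on these cores would look like.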